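The source may hold more compounds than are shown below. What is called first, only, known or untested is meant among the compounds shown, and "the series" means these compounds.

Two compounds built on a shared core and each carrying a long chain have been measured in a functional assay on MDA-MB-231 cells (Homo sapiens) for antiproliferative activity, read by MTT assay; on this read-out higher numbers stand for weaker inhibition and lower numbers for stronger inhibition. Compound 1 `CC/C=C\C/C=C\C/C=C\CCCCCCCc1cc(=O)c2c(O)cc(O)cc2o1` gives 6790 nM in this assay. Compound 2 `CCCCC/C=C\C/C=C\CCCCCCCc1cc(=O)c2c(O)c(C)c(O)cc2o1` gives 16100 nM in this assay, the higher of the two numbers shown; its nearest neighbour is compound 1, whose number lies lower by a margin beyond the usual scatter. Compound 3 `CCCCC/C=C\C/C=C\CCCCCCCc1cc(=O)c2c(O)cc(O)cc2o1` has not yet been measured in this assay. From compound 2 to compound 3 the change is hydrogen in place of methyl on an aromatic carbon. For the measured compounds named here, no measured pair differs in this one place, so the data at hand give no direct guide to the size or direction of such a step. A modest step toward a lower number is expected, though a step within the scatter is also plausible. Compound 3 is estimated at 9500 nM, within a range from 4000 nM to 25000 nM. The step implied by this estimate is expected to be a 1.7-fold lower number from compound 2 to compound 3 (0.23 log units; within the scatter).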

Compound 3, half-maximal inhibitory concentration: 6790 nM
Compound 3: the middle estimate sits 1.4-fold (0.15 log units) above what was measured; the range from low to high includes it.
By their numbers in this assay, from the lowest: compounds 1 and 3 (each within the scatter of the next); then compound 2.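

In this assay, for the compounds shown here, hydrogen in place of methyl on the aromatic carbon ortho to two hydroxy groups gives a 2.4-fold lower number from compound 2 to compound 3 (0.37 log units; beyond the scatter) on the shared core, the first direct reading for this place, and it shows that the methyl comes with weaker inhibition in this pair. The other change, butyl in place of but-1-en-1-yl at the end of the chain, gives no change at the digits printed from compound 1 to compound 3 (within the scatter) and so shows no sign of mattering in this assay. Nothing available bears on why hydrogen and methyl differ here.

As far as these compounds go, whether the step is tied to methyl itself stays open, and an ethyl group or a chlorine atom on the same carbon would help to settle that. From the compounds shown here alone, it is also open whether the methyl step would be the same with the but-1-en-1-yl chain or with a longer chain.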